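The source may hold more compounds than are shown below. What is called first, only, known or untested is meant among the compounds shown, and "the series" means these compounds.

Three compounds share one core and differ only in the group attached at the end of a triple bond. Compound 1 `CNC(=O)[C@@]12C[C@@H]1[C@@H](n1cnc3c(NC)nc(C#Cc4ccc(-c5ccccc5)cc4)nc31)[C@H](O)[C@@H]2O` gives 18% in an assay on CHO cells for displacement of a labelled ligand from adenosine receptor A1 (Homo sapiens), read by scintillation counting, with a stated time of 60 min, tested at 10 uM; on this read-out lower numbers stand for less inhibition and higher numbers for more inhibition at the one concentration tested (going by the name of the read-out). Compound 2 `CNC(=O)[C@@]12C[C@@H]1[C@@H](n1cnc3c(NC)nc(C#Cc4ccc(OC)cc4)nc31)[C@H](O)[C@@H]2O` gives 10% in this assay, and compound 3 `CNC(=O)[C@@]12C[C@@H]1[C@@H](n1cnc3c(NC)nc(C#Cc4cccnc4)nc31)[C@H](O)[C@@H]2O` gives 16%. Among these three numbers compound 3 stands second highest; its nearest neighbour is compound 1, with a number 2 percentage points lower from compound 1 to compound 3 (within the scatter), and its furthest is compound 2, with a number 6 percentage points higher from compound 2 to compound 3 (within the scatter). Both of those steps lie within the scatter, as does a number 8 percentage points lower from compound 1 to compound 2 (within the scatter), so the three compounds cannot be told apart on this read-out.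

Compound 4 `CNC(=O)[C@@]12C[C@@H]1[C@@H](n1cnc3c(NC)nc(C#Cc4cc5ccccc5o4)nc31)[C@H](O)[C@@H]2O` is the next member of the series. The change from compound 3 is 1-benzofuran-2-yl in place of pyridin-3-yl on a triple-bonded carbon. Going by the values given here, the steps that bear on it are the two earlier swaps of the group on the triple-bonded carbon, a number 2 percentage points lower from compound 1 to compound 3 (within the scatter) and a number 6 percentage points higher from compound 2 to compound 3 (within the scatter), and neither moved the number beyond the scatter. A further swap at the same place is therefore expected to give no change at the digits printed from compound 3 to compound 4 (within the scatter), with no shift beyond the scatter. Compound 4 is estimated at 16%, between 4% and 32%.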

Compound 4, a percentage reported as inhibition, at one concentration (the size of the read-out at that concentration, not a potency): 13%
For compound 4 the middle estimate is 3 percentage points above the measured one; low and high end bracket the measured number.
By their numbers in this assay, from the lowest: compounds 2, 4, 3 and 1 (each within the scatter of the next).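

Putting 1-benzofuran-2-yl on the triple-bonded carbon brings a five-membered aromatic ring with oxygen as its hetero atom into a place that otherwise holds only six-membered aromatic rings, and in this assay the three steps to it are a number 3 percentage points lower from compound 3 to compound 4 (within the scatter) and a number 3 percentage points higher from compound 2 to compound 4 (within the scatter) and a number 5 percentage points lower from compound 1 to compound 4 (within the scatter). So this new kind of ring does not set compound 4 apart from the other three on this read-out, and the four numbers remain a single group with no order among them. Nothing available here explains why the number holds steady across these different ring groups.

Every group at the end of the triple bond shown here contains an aromatic ring, so it stays open whether an amine, a carboxylic acid or a longer alkyl chain at this place would move the number beyond the scatter. Also open, as far as these compounds go, is whether a change elsewhere on the shared core, such as at the methylamide, would shift the number in a way that these swaps at the triple bond do not.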